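This account rests on a few compounds, and the source may have more. Where it says the series, first, only, none or still open, it means among the compounds named here.

Measured so far:
compound 1 `COc1cccc(CNCCCNc2ccnc3cc(-c4ccc(C(C)(C)C)cc4)ccc23)c1O` gives 9.47 in a physicochemical assay for acid dissociation
compound 2 `COc1cccc(CNCCCNc2ccnc3cc(Cc4ccc(F)cc4)ccc23)c1O` gives 9.47 in this assay
compound 3 `COc1ccccc1Oc1ccc2c(NCCCNCc3cccc(OC)c3O)ccnc2c1` gives 9.28 in this assay

Compound 3 holds the lowest of the three numbers, but its distance to each neighbour is small: a number 0.19 log units lower from compound 1 to compound 3 (within the scatter) and a number 0.19 log units lower from compound 2 to compound 3 (within the scatter) both lie within the scatter, as does no change at the digits printed from compound 1 to compound 2 (within the scatter). Compound 4 `COc1cccc(CNCCCNc2ccnc3cc(Oc4ccc(Cl)cc4)ccc23)c1O` differs from compound 3 by 4-chlorophenyl in place of 2-methoxyphenyl on an oxygen on an aromatic ring. Within the data shown here, the steps that bear on this are the two in which the group on that aromatic carbon was exchanged, each within the scatter, so the exchange of one ring for another on the oxygen is expected to give no step beyond the scatter: a number 0.07 log units higher from compound 3 to compound 4 (within the scatter). Compound 4 is therefore estimated at 9.35, within 9.05 to 9.65.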

Compound 4, acid dissociation constant: 9.28
Compound 4: the middle estimate sits 0.07 log units above what was measured; the range from low to high includes it.
By their numbers in this assay, from the lowest: compounds 3, 4, 1 and 2 (each within the scatter of the next).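

In this assay, among these compounds, no change at the digits printed from compound 3 to compound 4 (within the scatter) is the first step in which only the ring on the oxygen changes, and exchanging 2-methoxyphenyl for 4-chlorophenyl leaves the number within the scatter. Both a number 0.19 log units lower from compound 2 to compound 4 (within the scatter) and a number 0.19 log units lower from compound 1 to compound 4 (within the scatter) also stay within the scatter, so the 4-chlorophenoxy group joins the three other groups on that aromatic carbon without separating from them.

The compounds shown leave open whether an amine or a carboxylic acid on that aromatic carbon, or a longer chain in the shared core, would give a step beyond the scatter. No measurement at hand explains why these numbers stay so close.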